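Fluoro for methoxy on the benzoyl aryl of compound 1

This account rests on a few compounds, and the source may have more. Where it says the series, first, only, none or still open, it means among the compounds named here.

Working notes on the series. In an assay on isolated protein for inhibition of histone deacetylase 8 (Homo sapiens) (on this read-out higher numbers stand for weaker inhibition and lower numbers for stronger inhibition), compound 1 `COc1ccc(C(=O)c2ccc3c(ccn3S(=O)(=O)c3cccc(/C=C/C(=O)NO)c3)c2)cc1` gives 812 nM, the lowest of the two numbers shown. Compound 2 `COc1ccc(C(=O)c2ccc3c(ccn3Cc3ccc(/C=C/C(=O)NO)cc3)c2)cc1` gives 2810 nM in this assay. Compound 3 `O=C(/C=C/c1cccc(S(=O)(=O)n2ccc3cc(C(=O)c4ccc(F)cc4)ccc32)c1)NO` is not yet measured; it differs from compound 1 by fluoro in place of methoxy on an aromatic carbon. Going by the values given here, no step between measured compounds bears on this change, so the expectation rests on compound 1 alone: a step no larger than the scatter is expected, as a 1.1-fold higher number from compound 1 to compound 3 (0.04 log units; within the scatter), in no firm direction. Compound 3 is therefore estimated at 900 nM, expected within 350 nM to 2500 nM in this assay.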

Compound 3, half-maximal inhibitory concentration: 2750 nM
For compound 3 the middle estimate is 3.1-fold (0.49 log units) below the measured one; measured number above the stated range.
By their numbers in this assay, from the lowest: compound 1; then compounds 3 and 2 (each within the scatter of the next).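

In this assay, going from 4-methoxyphenyl to 4-fluorophenyl gives a 3.4-fold higher number from compound 1 to compound 3 (0.53 log units; beyond the scatter) and so shows that inhibition responds to the group at this position. This rests on a single pair and holds only for the core of compound 1. Nothing on hand explains the step.

Going by these compounds, whether the loss follows from removing methoxy or from introducing fluoro stays open, and a hydroxyl, an ethoxy or an amine at this position could help separate the two. Also open, on these data alone, is whether the same exchange gives a similar step on the core of compound 2.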